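A few compounds are considered here, and "the series" means these few. Any claim that something is new, unique, unknown or untested is made for them only; others in the source may bear on it.

Working notes on the series.

Two compounds have been run in a functional assay for inhibition, with Homo sapiens as the target (on this read-out higher numbers stand for weaker inhibition and lower numbers for stronger inhibition), so far, and neither returned a number. Compound 1, `O=C(CSc1nncc2cncn12)c1ccccc1`, reached only the limit of the assay, reported as > 48000 nM. Compound 2, `CCCc1nc(C)c2cnn(C/C=C/C(=O)OCC)c(=O)n12`, likewise stopped at the limit, reported as > 48000 nM. On the numbers shown, compound 2 therefore stands at the ceiling of this assay, together with the other measured compound: the limit of > 48000 nM in this assay, at which 2 of the 2 values shown sit. For the measured compounds named here, no measured step between two compounds differing in one place exists in this set, so no step size has yet been observed.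

The next compound, compound 3, `CCCc1nc(C)c2cnn(CC)c(=O)n12`, differs from compound 2 by methyl in place of 2-(ethoxycarbonyl)ethenyl on a saturated chain carbon bound to an aromatic nitrogen. Since compound 2 sits at the limit in this assay, the expectation for compound 3 is that the change moves nothing beyond the usual scatter, and that compound 3 will most likely again be reported as a limit rather than a number. Compound 3 is expected at 60000 nM in this assay, within a range from 20000 nM to 200000 nM. The step that this estimate implies, a step that the limit leaves unreadable from compound 2 to compound 3, is expected to be no larger than the scatter.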

Compound 3, half-maximal inhibitory concentration: > 48000 nM
Compound 3 gave a limit, no number; the forecaster's own chance of this, stated with the estimate: 85%; the middle value lies beyond the limit too.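

No step can be read between compound 2 and compound 3, because each of the two results is a limit and not a number: the limit of > 48000 nM in this assay, at which 3 of the 3 values shown sit.

The compounds shown leave open whether any group on this series can bring a readable value in this assay, and what replacing 2-(ethoxycarbonyl)ethenyl with methyl does to inhibition.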